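Swapping Chloro for Methoxy on Two Related Cores

The source may report more compounds than this note shows. Statements on the series, on what has been measured and on what is new or still open speak of the compounds shown alone.

Compound 1 `CC(=O)c1cccn1CCCN1CCN(c2cccc(Cl)c2)CC1` and compound 2 `COc1cccc(N2CCN(CCCn3cccc3C(C)=O)CC2)c1` share one core; compound 3 `O=c1occ(-c2ccccc2)n1CCCN1CCN(c2cccc(Cl)c2)CC1` and compound 4 `COc1cccc(N2CCN(CCCn3c(-c4ccccc4)coc3=O)CC2)c1` share another. How the two cores differ is not broken down here. In a functional assay on the whole organism (Abdomen, strain Swiss) for inhibition, with Mus musculus as the target, with stated times of 30 min, 10 min and 5 min, at a dose of 20 mg/kg by the oral route (on this read-out lower numbers stand for a weaker effect and higher numbers for a stronger effect at the one dose given), compound 1 gives 41%, and compound 2 gives 26%. The change between them, (methoxy in place of chloro on an aromatic carbon), produced a number 15 percentage points lower from compound 1 to compound 2 (beyond the scatter). In this assay compound 3 gives 31%, a number within the usual scatter of both earlier values. The change from compound 3 to compound 4, (methoxy in place of chloro on an aromatic carbon), is the same change, made at the same place on the ring. Compound 4 is not yet measured. A step of a number 15 percentage points lower from compound 3 to compound 4 (beyond the scatter) is expected, resting on the earlier pair because the same change produced a number 15 percentage points lower from compound 1 to compound 2 (beyond the scatter). Compound 4 is therefore estimated at 16%, most likely falling between 2% and 32%.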

Compound 4, a percentage reported as inhibition, in the whole organism at one dose (the size of the read-out at that dose, not a potency): 25%
Estimate against measurement, compound 4: 9 percentage points below; low and high end bracket the measured number.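

In this assay, methoxy in place of chloro gives a number 6 percentage points lower from compound 3 to compound 4 (within the scatter). As far as these numbers can tell, the change carries from the core of compound 1 to the core of compound 3 without a real disagreement between the two steps: the same change on two cores in this assay, a number 15 percentage points lower (beyond the scatter) from compound 1 to compound 2 and a number 6 percentage points lower (within the scatter) from compound 3 to compound 4, 9 percentage points apart, within the scatter of two such steps

Going by these compounds alone, this does not show that the change acts equally on both cores: there are only two pairs, one step lies beyond the scatter and the other within it, and each rests on a single dose. From the compounds shown here alone, whether a hydroxy or a trifluoromethyl group in the place of chloro would follow the same course stays open. So does whether the step would hold on a third core or with a longer chain.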